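Replacing Isopentyloxy with (2-Chlorobenzyl)sulfanyl in Compound 4

This account rests on a few compounds, and the source may have more. Where it says the series, first, only, none or still open, it means among the compounds named here.

Three measured analogues share one core. Compound 1 `CCCN(CCC)c1nc(C(C)(C)C)ccc1CNC(=O)C(C)c1ccc(NS(C)(=O)=O)c(F)c1` gives 2.5 nM in an assay on cells for antagonist activity at transient receptor potential cation channel subfamily V member 1 (Homo sapiens), read by FLIPR and calcium flux, with a stated time of 6 min; a lower number here means a stronger inhibitor, a higher number a weaker inhibitor. Compound 2 `CC(C)COc1nc(C(C)(C)C)ccc1CNC(=O)C(C)c1ccc(NS(C)(=O)=O)c(F)c1` gives 0.6 nM in this assay, and compound 3 `CC(C)CCOc1nc(C(C)(C)C)ccc1CNC(=O)C(C)c1ccc(NS(C)(=O)=O)c(F)c1` gives 0.8 nM in this assay. Among these three numbers compound 3 stands second highest; its nearest neighbour is compound 2, with a 1.3-fold higher number from compound 2 to compound 3 (0.12 log units; within the scatter), while a 3.1-fold lower number from compound 1 to compound 3 (0.49 log units; beyond the scatter) and a 4.2-fold lower number from compound 1 to compound 2 (0.62 log units; beyond the scatter) both lie beyond the scatter.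

Compound 4 `CC(C(=O)NCc1ccc(C(C)(C)C)nc1SCc1ccccc1Cl)c1ccc(NS(C)(=O)=O)c(F)c1` differs from compound 3 by (2-chlorobenzyl)sulfanyl in place of isopentyloxy on an aromatic carbon. Within the data shown here, none of the measured steps bears closely on this change: the two larger steps replace dipropylamino with an alkoxy chain, and the one step within the alkoxy series, isobutyl for isopropyl, stays within the scatter. The present change swaps the oxygen for sulfur and adds an aromatic ring, for which no comparison exists. In this assay compound 4 is therefore expected to show a step no larger than modest, a 1.9-fold higher number from compound 3 to compound 4 (0.27 log units; within the scatter), leaning slightly weaker. Compound 4 is estimated at 1.5 nM, with a range from 0.4 nM to 6 nM.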

Compound 4, inhibition constant: 3.8 nM
For compound 4 the middle estimate is 2.5-fold (0.40 log units) below the measured one; low and high end bracket the measured number.
By their numbers in this assay, from the lowest: compounds 2 and 3 (each within the scatter of the next); then compounds 1 and 4 (each within the scatter of the next).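

The position next to the ring nitrogen proves more demanding than the two alkoxy compounds suggested. In this assay, (2-chlorobenzyl)sulfanyl in place of isopentyloxy gives a step beyond the scatter (a 4.8-fold higher number from compound 3 to compound 4 (0.68 log units; beyond the scatter)), and so does the same group in place of isobutoxy (a 6.3-fold higher number from compound 2 to compound 4 (0.80 log units; beyond the scatter)), whereas the change from dipropylamino stays within it (a 1.5-fold higher number from compound 1 to compound 4 (0.18 log units; within the scatter)), leaving the two alkoxy compounds apart from both others. No evidence is available to account for these steps.

The sulfur and the 2-chlorobenzyl ring enter together, so the compounds shown leave open which of them goes with the step; a benzyloxy group or an isopentylsulfanyl chain at this place would separate the two. Going by these compounds, whether a smaller amine, such as dimethylamino, would sit with the alkoxy compounds or with compound 1 also stays open.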